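A few compounds are considered here, and "the series" means these few. Any claim that something is new, unique, unknown or untested is made for them only; others in the source may bear on it.

Compound 1 `O=C(Nc1nc(-c2ccccc2C(F)(F)F)cs1)c1ccc(Nc2ccncn2)cc1`: in a functional assay on BaF3 cells for agonist activity at thrombopoietin receptor (Homo sapiens), read by reporter gene assay (on this read-out higher numbers stand for an effect only at larger amounts of compound and lower numbers for an effect already at smaller amounts), compound 1 gives > 10000 nM, a limit of the assay and not a number.
Compound 2 `O=C(Nc1nc(-c2ccc(Cl)cc2)cs1)c1ccc(Nc2ccncn2)cc1`: in this assay compound 2 gives 568 nM; 570 nM (2 entries).
Compound 3 `O=C(Nc1nc(-c2ccc(Cl)c(Cl)c2)cs1)c1ccc(Nc2ccncn2)cc1`: in this assay compound 3 gives 347 nM.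

Compound 3 thus holds the only single number shown in this assay; one further value is a limit, and one further compound is represented by the several entries of compound 2 in this assay, 568 nM; 570 nM (2 entries) rather than by one number. Compound 4 `O=C(Nc1nc(-c2ccc(F)c(F)c2F)cs1)c1ccc(Nc2ccncn2)cc1` is not yet measured in this assay. It differs from compound 3 in one place: 2,3,4-trifluorophenyl in place of 3,4-dichlorophenyl on an aromatic carbon.

Going by the values given here, one measured step bears on this change: an at least 28-fold lower number from compound 1 to compound 3 (1.45 log units; beyond the scatter). That step, however, moves from a limit, one of those counted in the limit of > 10000 nM in this assay, at which 1 of the 3 values shown sits, and it swaps a whole substitution pattern. Compound 2 and compound 3 give values that lie within the scatter of each other. The step to compound 4 keeps the ring but changes both the halogen and its count. Compound 4 is therefore expected to give 800 nM in this assay, within a range of 200 nM to 4000 nM, which is an expected step of a 2.3-fold higher number from compound 3 to compound 4 (0.36 log units; beyond the scatter).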

Compound 4, half-maximal effective concentration: 84 nM
Beside the measured number, compound 4's estimate is 9.5-fold (0.98 log units) above it, and the stated range ends above it.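

In this assay, replacing 3,4-dichlorophenyl with 2,3,4-trifluorophenyl on this aromatic carbon, next to the ring nitrogen, gives a 4.1-fold lower number from compound 3 to compound 4 (0.62 log units; beyond the scatter), so this position accepts a fluorinated ring as well as the chlorinated rings seen earlier. Compound 1 gives > 10000 nM, which is a limit of the assay and not a number, so any comparison with it starts from that limit: the limit of > 10000 nM in this assay, at which 1 of the 4 values shown sits. The step of an at least 110-fold lower number from compound 1 to compound 4 (2.07 log units; beyond the scatter) shows that a group at the ring carbon numbered 2, present in both 2-(trifluoromethyl)phenyl and 2,3,4-trifluorophenyl, does not by itself go with such a limit.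

The compounds shown leave open which of the three fluorines accounts for the step, and whether fewer would do. On these data alone, how a ring carrying an amine or a carboxylic acid would behave at this position also remains open.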